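Removing the Last Hydroxy Group from Compound 3

The source may report more compounds than this note shows. Statements on the series, on what has been measured and on what is new or still open speak of the compounds shown alone.

In a functional assay on HepG2 cells (Homo sapiens) for inhibition, read by MTT assay, with a stated time of 48 h (a higher number here means a weaker inhibitor, a lower number a stronger inhibitor), compound 1 `COc1cc(C(=O)/C=C/c2cc(O)ccc2O)cc(OC)c1OC` gives > 100000 nM, which is a limit of the assay and not a number. Compound 2 `COc1cc(C(=O)/C=C/c2ccc(O)c(O)c2)cc(OC)c1OC` gives 14900 nM, and compound 3 `COc1cc(C(=O)/C=C/c2cccc(O)c2)cc(OC)c1OC` gives 94000 nM, the higher of the two actual numbers. Compound 4 `COc1cc(C(=O)/C=C/c2ccc(F)cc2)cc(OC)c1OC` has 4-fluorophenyl in place of 3-hydroxyphenyl on a double-bonded chain carbon bound to a double-bonded chain carbon.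

Going by the values given here, two measured steps bear on this change. Losing a hydroxy group gave a 6.3-fold higher number from compound 2 to compound 3 (0.80 log units; beyond the scatter), a modest step beyond the scatter. The same kind of change gave an at least 1.0-fold lower number from compound 1 to compound 3 (0.02 log units; that floor lies within the scatter), whose floor lies within the scatter. Moving the hydroxy groups gave an at least 6.7-fold lower number from compound 1 to compound 2 (0.82 log units; beyond the scatter). All of these steps concern hydroxy groups, and none tests a fluorine, so they give no firm direction in this assay.

An estimated step of a 1.6-fold lower number from compound 3 to compound 4 (0.19 log units; within the scatter) is expected, with no change beyond the scatter. For compound 4 the expected value is 60000 nM, with an estimated range of 15000 nM to 130000 nM.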

Compound 4, half-maximal inhibitory concentration: 22000 nM
The estimate for compound 4 lay 2.7-fold (0.44 log units) above the measured number; the range from low to high includes it.
By their numbers in this assay, from the lowest: compounds 2 and 4 (each within the scatter of the next); then compound 3. At a limit, above all of these: compound 1.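

In this assay, 4-fluorophenyl in place of 3-hydroxyphenyl gave a 4.3-fold lower number from compound 3 to compound 4 (0.63 log units; beyond the scatter), so a hydroxy group on this ring is not needed to reach the lower numbers among these compounds. Going by these compounds alone, the change from 3,4-dihydroxyphenyl to 4-fluorophenyl gave a 1.5-fold higher number from compound 2 to compound 4 (0.17 log units; within the scatter), a step within the scatter, so a ring with 0 hydrogen-bond donors reads no differently here from the one with two hydroxy groups. With 2,5-dihydroxyphenyl as the group replaced, the change gave an at least 4.5-fold lower number from compound 1 to compound 4 (0.65 log units; beyond the scatter), a floor and not a size, as the starting value is a limit: the limit of > 100000 nM in this assay, at which 1 of the 4 values shown sits.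

On these data alone, whether the fluorine itself or only the loss of the hydroxy carries the step from 3-hydroxyphenyl remains open, as does how an unsubstituted phenyl would compare. Also open, as far as these compounds go, is how an amine or a carboxylic acid on this ring would read.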